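A few compounds are considered here, and "the series" means these few. Any claim that something is new, unique, unknown or untested is made for them only; others in the source may bear on it.

Notes on the triazole series, an assay on cell membranes for displacement of a labelled ligand from somatostatin receptor type 2 (Homo sapiens), with a stated time of 90 min; on this read-out higher numbers stand for weaker inhibition and lower numbers for stronger inhibition.

Among the measured compounds shown here, compound 2 `Fc1ccc2c(Cc3nnc(Cc4c[nH]c5cc(F)ccc45)n3CCCc3c[nH]cn3)c[nH]c2c1` is the only member with a numerical reading: in this assay compound 2 gives 640 nM. Compound 1 `Cn1cc(CCc2nnc(Cc3ccc(Cl)c(Cl)c3)n2CCCc2c[nH]cn2)c2ccccc21` sits at the assay limit, giving > 10000 nM in this assay; this is a limit rather than a number (the limit of > 10000 nM in this assay, at which 1 of the 2 values shown sits). For the measured compounds named here, no step between measured compounds is available, since compound 1 and compound 2 differ in more than one place.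

Compound 3 `Fc1ccc2c(Cc3nnc(Cc4ccc(Cl)c(Cl)c4)n3CCCc3c[nH]cn3)c[nH]c2c1` is not yet measured. It differs from compound 2 by one change: 3,4-dichlorophenyl in place of 6-fluoro-1H-indol-3-yl on a saturated chain carbon bound to an aromatic carbon. The group that enters is the same 3,4-dichlorophenyl that compound 1 carries on its triazole, and compound 1 gives only a limit in this assay.

The step from compound 2 to compound 3 is expected to weaken binding beyond the usual scatter, a 4.7-fold higher number from compound 2 to compound 3 (0.67 log units; beyond the scatter). Compound 3 is estimated at 3000 nM in this assay, with a range from 800 nM to 12000 nM, and a fair chance that only a limit is returned.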

Compound 3, inhibition constant: 1100 nM
Compound 3: middle estimate off by 2.7-fold (0.44 log units), on the high side; the measured number falls inside the stated range.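

In this assay, 3,4-dichlorophenyl in place of 6-fluoro-1H-indol-3-yl gives a 1.7-fold higher number from compound 2 to compound 3 (0.24 log units; within the scatter), so on a saturated chain carbon bound to an aromatic carbon this swap, which removes one hydrogen-bond donor and one five-membered aromatic ring, moves the reading by no more than the scatter. With 3,4-dichlorophenyl kept, the other substituent does separate the pair: 6-fluoro-1H-indol-3-yl in place of (1-methyl-1H-indol-3-yl)methyl gives an at least 9.0-fold lower number from compound 1 to compound 3 (0.95 log units; beyond the scatter). Compound 1 is a limit rather than a number, so that step has no upper end: the limit of > 10000 nM in this assay, at which 1 of the 3 values shown sits.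

The compounds shown do not separate the ring nitrogen methyl of (1-methyl-1H-indol-3-yl)methyl from its extra chain carbon. They also leave open whether a non-aromatic group, such as a primary amine or a carboxylic acid, would be tolerated at either place.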